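Swapping a Hydroxy for a Methyl in a Glutamate Modulator

A few compounds are considered here, and "the series" means these few. Any claim that something is new, unique, unknown or untested is made for them only; others in the source may bear on it.

Compound 2 `Cc1c(OCCCCOc2cccc(C(=O)O)c2)ccc(C(=O)CC2CCCC2)c1O` was tested in an assay on HEK293 cells for positive allosteric modulation of metabotropic glutamate receptor 2 (Rattus norvegicus), read by thallium flux, with a stated time of 2.5 min (on this read-out lower numbers stand for an effect already at smaller amounts and higher numbers for an effect only at larger amounts of compound), where compound 2 gives 451 nM. Going by the values given here, compound 3 `Cc1ccc(C(=O)O)cc1OCCCCOc1ccc(C(=O)CC2CCCC2)c(O)c1C` gives 1290 nM, and the single change between the two, methyl in place of hydrogen on an aromatic carbon, produces a 2.9-fold higher number from compound 2 to compound 3 (0.46 log units; beyond the scatter). Compound 1 `COC(=O)c1ccc(OCCCCOc2ccc(C(=O)CC3CCCC3)c(C)c2C)cc1` has no number in this assay: for compound 1 the entry is "not determined" (no result reported). Of the two measured numbers, compound 2 stands lowest. Compound 4 `Cc1c(OCCCCOc2cccc(C(=O)O)c2)ccc(C(=O)CC2CCCC2)c1C` differs from compound 2 by methyl in place of hydroxy on an aromatic carbon. Among the compounds with values here, no measured pair tracks this exchange; the only measured step touches a different aromatic carbon and gives no direction for it. A step of modest size is therefore expected, a 1.7-fold higher number from compound 2 to compound 4 (0.22 log units; within the scatter). Compound 4 is estimated at 750 nM, with a range from 250 nM to 2200 nM.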

Compound 4, half-maximal effective concentration: "not active" (no number reported)
Nothing numeric was reported for compound 4, and the estimate cannot be compared.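

Compound 4 has no number, so no step from compound 2 to compound 4 can be read, and no measurement shown accounts for this. On these data alone, what stays open is how far methyl in place of hydroxy shifts the result in this assay.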